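A few compounds are considered here, and "the series" means these few. Any claim that something is new, unique, unknown or untested is made for them only; others in the source may bear on it.

Among the compounds with values here, compound 3 `CC1=C(/C=C/C(C)=C/C=C/C(C)=C\C(=O)NCc2cccc(F)c2)C(C)(C)CCC1n1ccnc1` sits second highest of the three numbers so far in a functional assay on SK-BR-3 cells (Homo sapiens) for inhibition, read by MTT assay (a lower number here means a stronger inhibitor of growth, a higher number a weaker inhibitor of growth), giving 4240 nM. Its nearest neighbour is compound 2 `CC1=C(/C=C/C(C)=C/C=C/C(C)=C\C(=O)NCc2ccc(O)cc2)C(C)(C)CCC1n1ccnc1`, which in this assay gives 2450 nM; the step of a 1.7-fold higher number from compound 2 to compound 3 (0.24 log units; within the scatter) is within the scatter. Furthest away is compound 1 `CC1=C(/C=C/C(C)=C/C=C/C(C)=C\C(=O)Nc2ccccc2)C(C)(C)CC=C1c1cccnc1`, which in this assay gives 47400 nM, a higher number that lies beyond the scatter; compound 1 also differs in its core, so nothing more is read from that pair.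

Compound 4 `CC1=C(/C=C/C(C)=C/C=C/C(C)=C\C(=O)NCc2ccccc2)C(C)(C)CCC1n1ccnc1` is the next member. Relative to compound 3 the change is hydrogen in place of fluoro on an aromatic carbon. Within the data shown here, the only measured step that touches the same aromatic ring is the one from compound 2 to compound 3, where the whole substituent pattern of that ring was exchanged and the number moved only within the scatter. Among the measured compounds shown here, removing a single fluoro from that ring is a smaller alteration than that exchange, and no step in the set shows a fluoro on this ring carrying weight of its own.

The step of a 1.1-fold lower number from compound 3 to compound 4 (0.03 log units; within the scatter) is therefore expected to stay within the scatter. For compound 4 the estimate in this assay is 4000 nM, with a range from 1800 nM to 9000 nM.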

Compound 4, concentration for 50% growth inhibition: 10700 nM
Compound 4: the middle estimate sits 2.7-fold (0.43 log units) below what was measured; the measured number lies above the stated range.
By their numbers in this assay, from the lowest: compounds 2 and 3 (each within the scatter of the next); then compound 4; then compound 1.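

In this assay the aromatic carbon that carries the fluoro in compound 3 turns out not to be silent: with hydrogen there, the step is a 2.5-fold higher number from compound 3 to compound 4 (0.40 log units; beyond the scatter), so a single atom change on this ring can register beyond the scatter. Replacing the hydroxy of compound 2 with hydrogen moves the number further, with the step of a 4.4-fold higher number from compound 2 to compound 4 (0.64 log units; beyond the scatter), and this makes the unsubstituted phenyl of compound 4 the reference that the earlier pair lacked. Both fluoro and hydroxy give lower numbers than hydrogen on this ring, while compounds 2 and 3 remain within the scatter of each other, so the earlier step between them concealed that each substituent differs from the bare ring; this holds for these three compounds only.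

Nothing among the data given accounts for this difference between hydrogen and the two substituents. From the compounds shown here alone, it remains open whether a chloro, a methoxy or an amine on this ring would also lower the number, and whether a longer chain between the amide nitrogen and the ring would preserve the effect of these substituents.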